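Trimethoxyphenyl series: dichlorophenyl swap on the saturated ring

The source may hold more compounds than are shown below. What is called first, only, known or untested is meant among the compounds shown, and "the series" means these compounds.

Measured so far:
compound 1 `COc1cc(C2=NN(C(C)=O)C(c3cccc(OC)c3OC)O2)cc(OC)c1OC` — 3.8%
compound 2 `COc1cc(C(=O)N/N=C/c2cccc(C(F)(F)F)c2)cc(OC)c1OC` — 17.7%

In a functional assay on BGC-823 cells (Homo sapiens) for antiproliferative activity, read by MTT assay, tested at 1 uM (on this read-out lower numbers stand for a weaker effect and higher numbers for a stronger effect at the one concentration tested), compound 1 gives 3.8%, the lowest of the two numbers; compound 2 gives 17.7%, a gap beyond the scatter, but the two share no single-point difference, so only the two values themselves can be read. Compound 3 `COc1cc(C2=NN(C(C)=O)C(c3ccc(Cl)c(Cl)c3)O2)cc(OC)c1OC` differs from compound 1 by 3,4-dichlorophenyl in place of 2,3-dimethoxyphenyl on a saturated ring carbon. Among the compounds with values here, no comparable step is available in this assay, so only a modest rise, if any, is expected, with a shift of a number 6.2 percentage points higher from compound 1 to compound 3 (within the scatter). For compound 3 the estimate in this assay is 10%, ranging from 0% to 28%.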

Compound 3, a percentage reported as inhibition, at one concentration (the size of the read-out at that concentration, not a potency): -0.8%
Compound 3: the middle estimate sits 10.8 percentage points above what was measured; the whole stated range lies above it.
By their numbers in this assay, from the lowest: compounds 3 and 1 (each within the scatter of the next); then compound 2.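

In this assay, 3,4-dichlorophenyl in place of 2,3-dimethoxyphenyl on the saturated ring carbon gives a number 4.6 percentage points lower from compound 1 to compound 3 (within the scatter). At this position, then, exchanging a phenyl with two methoxy groups for one with two chlorines does not separate the two compounds at the one concentration tested. Nothing available bears on why this exchange leaves the read-out within the scatter.

On these data alone, whether an amine or a carboxylic acid on this phenyl would shift the read-out beyond the scatter remains open. Also open, as far as these compounds go, is whether replacing the acetyl group on the ring nitrogen with a longer chain would do so.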